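A few compounds are considered here, and "the series" means these few. Any claim that something is new, unique, unknown or untested is made for them only; others in the source may bear on it.

Compound 1 `CC(C)(C)c1ccc(-c2ccc(NCc3ccccc3O)cc2)cc1` and compound 2 `CCOc1ccc(-c2ccc(NCc3ccccc3O)cc2)cc1F` share a core in which two six-membered aromatic rings are joined, with an amine-linked hydroxybenzyl arm on one side; they differ in the groups on the far ring. In a functional assay on Jurkat cells (Homo sapiens) for activation, with a stated time of 24 h (a lower number here means that less compound is needed, a higher number that more compound is needed for the effect), compound 1 gives "not active" (no number reported), which is a statement rather than a number, so compound 1 stands at no definite place on the scale. In this assay compound 2 gives 2530 nM, a weak effect. Compound 3 `CCCc1ccc(-c2ccc(NCc3ccccc3O)cc2)cc1` has not yet been measured. Its change from compound 1 is propyl in place of tert-butyl on an aromatic carbon. Nothing here shows how the tert-butyl group or the propyl group matters, so any step from compound 1 to compound 3 in this assay can only be guessed; the guess is that, if compound 3 shows any effect at all, it will be weak, and there is a fair chance that it, too, is reported without a number. Compound 3 is estimated at 6000 nM, expected to lie between 1500 nM and 25000 nM.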

Compound 3, half-maximal effective concentration: 2390 nM
Beside the measured number, compound 3's estimate is 2.5-fold (0.40 log units) above it; the range from low to high includes it.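

Within the data shown here, compound 1 carries no number in this assay, so no step from it to compound 3 can be read. The compounds shown leave open how far replacing tert-butyl with propyl alone changes the effect. No other evidence here bears on this result.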